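A few compounds are considered here, and "the series" means these few. Any claim that something is new, unique, unknown or untested is made for them only; others in the source may bear on it.

Measured so far:
- compound 1 `Oc1ccc2ccccc2c1/C=N/n1c(S)nnc1-c1cnccn1`: 69200 nM
- compound 2 `Oc1ccccc1/C=N/n1c(S)nnc1-c1cnccn1`: 75900 nM

In a functional assay, with a stated time of 30 min (a lower number here means a stronger inhibitor, a higher number a weaker inhibitor), compound 1 gives 69200 nM and compound 2 gives 75900 nM; the two numbers lie within the scatter of each other, so nothing separates them. Compound 3 `Oc1ccc(/C=N/n2c(S)nnc2-c2cnccn2)c(O)c1` has not yet been run in this assay. It differs from compound 2 by hydroxy in place of hydrogen on an aromatic carbon. Among the compounds with values here, no pair of measured compounds shows this kind of change, so there is no measured step to lean on. A step of no size beyond the scatter, in either direction, is expected for the move a 1.1-fold lower number from compound 2 to compound 3 (0.04 log units; within the scatter). Compound 3 is therefore estimated at 70000 nM, with a range from 25000 nM to 200000 nM.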

Compound 3, half-maximal inhibitory concentration: 75900 nM
Estimate against measurement, compound 3: 1.1-fold (0.04 log units) below; measured number inside the range.
By their numbers in this assay, from the lowest: compounds 1, 2 and 3 (each within the scatter of the next).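

In this assay, hydroxy in place of hydrogen on an aromatic carbon, meta to a hydroxy group and para to a large group, gives no change at the digits printed from compound 2 to compound 3 (within the scatter). Within the data shown here, this is the first reading for this change at this position, and the added hydroxy does not separate the two compounds. No supporting evidence accompanies this result.

Still open, on these data alone, is whether a methoxy group, an amine or a carboxylic acid on the same aromatic carbon would shift the number beyond the scatter. The compounds shown also leave open whether hydroxy at another carbon of this ring would do so.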